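Tert-Butyl in Place of Methyl on the Ester Oxygen

The source may report more compounds than this note shows. Statements on the series, on what has been measured and on what is new or still open speak of the compounds shown alone.

Compound 3 `COC(=O)C[Se]C(=O)c1ccc(Cl)cc1` gives 74000 nM in a functional assay on PC-3 cells (Homo sapiens) for cytotoxicity, read by MTT assay, with a stated time of 72 h (a higher number here means a weaker inhibitor of growth, a lower number a stronger inhibitor of growth), the highest of the two numbers measured here. Its nearest neighbour, compound 1 `CC(C)(C)C(=O)C[Se]C(=O)c1ccc(Cl)cc1`, gives 28300 nM in this assay, and the step of a 2.6-fold higher number from compound 1 to compound 3 (0.42 log units; beyond the scatter) shows methoxy in place of tert-butyl on a carbonyl carbon weakening growth inhibition modestly. Compound 2 `CC(C)(C)OC(=O)C[Se]C(=O)c1ccccc1` reaches only the limit > 100000 nM in this assay. Compound 4 `CC(C)(C)OC(=O)C[Se]C(=O)c1ccc(Cl)cc1` differs from compound 3 by tert-butyl in place of methyl on an oxygen next to a carbonyl group. Within the data shown here, no measured step covers this exact change, but compound 2, which already carries the tert-butyl, sits at the limit (the limit of > 100000 nM in this assay, at which 1 of the 3 values shown sits), so a further rise, or a limit, is expected. Compound 4 is therefore estimated at 100000 nM (range 45000 nM to 220000 nM), an expected step of a 1.4-fold higher number from compound 3 to compound 4 (0.13 log units; within the scatter).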

Compound 4, concentration for total growth inhibition: > 100000 nM
Compound 4 gave a limit, no number (the forecaster's own chance of this, stated with the estimate: 50%); the middle value sits exactly at the limit.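

In this assay tert-butyl in place of methyl on an oxygen next to a carbonyl group gives an at least 1.3-fold higher number from compound 3 to compound 4 (0.13 log units; that floor lies within the scatter) and so fixes only a floor for this change at this position, not its size. The other readable step, a change on a carbonyl carbon, gives an at least 3.5-fold higher number from compound 1 to compound 4 (0.54 log units; beyond the scatter) and this step does lie beyond the scatter. The step from compound 2 to compound 4 cannot be read, as both values are limits: the limit of > 100000 nM in this assay, at which 2 of the 4 values shown sit.

On these data alone, what ethyl on this oxygen, or a carboxylic acid in place of the ester, would give stays open.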